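The source may hold more compounds than are shown below. What is called first, only, known or untested is meant among the compounds shown, and "the series" means these compounds.

Measured compounds in a functional assay on the whole organism for inhibition, with Cicer arietinum as the target, with a stated time of 7 days; on this read-out lower numbers stand for stronger inhibition and higher numbers for weaker inhibition:

Compound 1 `CN(C)C(=S)SCc1nc2ccccc2[nH]1`: 2120 nM
Compound 2 `CCN(CC)C(=S)SCc1nc2ccccc2[nH]1`: 1860 nM
Compound 3 `O=C(CC(SC(=S)N1CCCCC1)c1ccccc1)c1ccccc1`: 1850 nM

Compound 3 stands alongside compounds 1 and 2 in this assay; its number lies within the scatter of both, so the three values show no separation.

Compound 4 `CCN(CC)C(=S)SC(CC(=O)c1ccccc1)c1ccccc1` differs from compound 3 in one place: diethylamino in place of piperidin-1-yl on a thiocarbonyl carbon. For the measured compounds named here, no measured pair shows this exact exchange. The nearest measured step concerns the same position on the thiocarbonyl carbon, namely the step from compound 1 to compound 2, which gave a 1.1-fold lower number from compound 1 to compound 2 (0.06 log units; within the scatter). That step swapped one acyclic dialkylamino group for another and moved nothing beyond the scatter. The change into compound 4 likewise keeps a dialkylamino group on the thiocarbonyl carbon, with the piperidin-1-yl ring opened into diethylamino. On that basis no step beyond the scatter is expected in this assay, and compound 4 is estimated at a 1.0-fold lower number from compound 3 to compound 4 (0.01 log units; within the scatter) relative to compound 3. Compound 4 is therefore expected near 1800 nM, with a range of 900 nM to 3600 nM.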

Compound 4, half-maximal inhibitory concentration: 1840 nM
The estimate for compound 4 lay 1.0-fold (0.01 log units) below the measured number, within the range that was stated.
By their numbers in this assay, from the lowest: compounds 4, 3, 2 and 1 (each within the scatter of the next).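

In this assay, exchanging piperidin-1-yl for diethylamino on the thiocarbonyl carbon gives a 1.0-fold lower number from compound 3 to compound 4 (0.00 log units; within the scatter), so within this pair the ring and the open-chain group are not told apart. For the compounds shown here, the earlier step, a 1.1-fold lower number from compound 1 to compound 2 (0.06 log units; within the scatter), exchanged only one open-chain dialkylamino group for another on a different core, whereas this pair shows that removing the ring from this position also leaves the number within the scatter. No supporting data are available to explain why the read-out holds across this exchange.

The compounds shown leave open whether any group at this position would produce a step beyond the scatter, for instance morpholin-4-yl, with its added ring oxygen, or dibutylamino, with its longer chains. They also leave open whether a monoalkylamino group, which keeps a hydrogen on the nitrogen, would behave like the dialkylamino groups seen so far.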